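The compounds below may be only part of what the source reports. "The series", "measured", "known", "first", "only" and "open" are said of these compounds alone.

Measured so far:
- compound 1 `O=C(O)CCCCCC[C@@H]1[C@@H](CC[C@@H](O)CCc2cccc(F)c2)[C@H](O)C[C@@H]1O`: 3700 nM
- compound 2 `Cc1ccccc1CC[C@H](O)CC[C@@H]1[C@@H](CCCCCCC(=O)O)[C@@H](O)C[C@H]1O`: > 10000 nM

For the measured compounds named here, compound 1 is the only member of the pair with a number in an in vitro assay on CHO-KI cells for displacement of a labelled ligand from prostaglandin E2 receptor EP3 subtype (Homo sapiens) (on this read-out higher numbers stand for weaker inhibition and lower numbers for stronger inhibition), where compound 1 gives 3700 nM. For compound 2 the result in this assay is a limit, > 10000 nM, not a number. Going by the values given here, the one measured step, an at least 2.7-fold higher number from compound 1 to compound 2 (0.43 log units; beyond the scatter), is therefore bounded from below only, as recorded in the limit of > 10000 nM in this assay, at which 1 of the 2 values shown sits.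

Compound 3 `CCc1cccc(CC[C@H](O)CC[C@@H]2[C@@H](CCCCCCC(=O)O)[C@@H](O)C[C@H]2O)c1` is not yet measured. Relative to compound 1 it carries ethyl in place of fluoro on an aromatic carbon. Among the compounds with values here, the only step that touches the same aromatic ring is an at least 2.7-fold higher number from compound 1 to compound 2 (0.43 log units; beyond the scatter), which altered both the group and its place on the ring and weakened binding. Compound 3 keeps the place and changes the group, so a smaller weakening, if any, is expected, given as a 1.9-fold higher number from compound 1 to compound 3 (0.28 log units; within the scatter). Compound 3 is estimated at 7000 nM in this assay, within 2500 nM to 20000 nM.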

Compound 3, half-maximal inhibitory concentration: > 10000 nM
Compound 3 gave a limit, no number; the forecaster's own chance of this, stated with the estimate: 35%; middle value at least 1.4-fold (0.15 log units) from the limit.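

Keeping the place on the ring and exchanging only the group, ethyl in place of fluoro, gives an at least 2.7-fold higher number from compound 1 to compound 3 (0.43 log units; beyond the scatter) in this assay. A change of place on the ring is therefore not needed for the loss of binding seen with compound 2, and in this pair the 3-fluorophenyl to 3-ethylphenyl exchange alone is sufficient. The result for compound 3 is a limit, so the step is bounded from one side only, and the step between compound 2 and compound 3 cannot be read: the limit of > 10000 nM in this assay, at which 2 of the 3 values shown sit.

Going by these compounds, how far the loss extends beyond that limit stays open, since compound 1 alone carries a number. Also open, on these data alone, is whether chloro or methoxy on the same aromatic carbon would give a number close to that of compound 1 or another limit.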